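Three Aromatic Amines, Three Assay Limits, One Open Question

The compounds below may be only part of what the source reports. "The series", "measured", "known", "first", "only" and "open" are said of these compounds alone.

Measured in a functional assay on COLO 205 cells (Homo sapiens) for cytotoxicity, read by MTT assay, with a stated time of 48 h; a lower number here means a stronger inhibitor, a higher number a weaker inhibitor:
Compound 1, `COc1ccccc1Nc1nc(-c2cccc(F)c2)nc2ccc(F)cc12`: > 50000 nM, a limit of the assay rather than a number.
Compound 2, `Fc1ccc(Nc2nc(-c3cccc(F)c3)nc3ccc(F)cc23)cc1`: > 50000 nM, again a limit.
Compound 3, `Fc1cccc(-c2nc(Nc3ccccc3F)c3cc(F)ccc3n2)c1`: > 50000 nM, again a limit.

Compound 3 stands at the limit of this assay, and the two other values shown stand there with it, so nothing separates the three. The step that the two limits leave unreadable from compound 1 to compound 2, the step that the two limits leave unreadable from compound 1 to compound 3 and the step that the two limits leave unreadable from compound 2 to compound 3 are all unreadable in size and direction because of the limit of > 50000 nM in this assay, at which 3 of the 3 values shown sit.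

Compound 4, `Fc1cccc(-c2nc(Nc3ccc(Cl)cc3)c3cc(F)ccc3n2)c1`, has not yet been measured in this assay. It differs from compound 3 in one place: 4-chlorophenyl in place of 2-fluorophenyl on a nitrogen on an aromatic ring. Within the data shown here, the step most alike in kind is the one from compound 2 to compound 3, where a fluorophenyl group on that same nitrogen was exchanged for another, and that step could not be read. Among the measured compounds shown here, no measured step therefore gives a size to expect in this assay; the three known values only say where the limit lies.

On that basis compound 4 is estimated to sit at 50000 nM, between 20000 nM and 200000 nM, most likely reported again as a limit. The expected step of a number no higher from compound 3 to compound 4 (the limit leaves the size open) is accordingly an estimate of no change that can be read.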

Compound 4, half-maximal inhibitory concentration: 32600 nM
Compound 4: the middle estimate sits 1.5-fold (0.19 log units) above what was measured; measured number inside the range.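

Among these compounds, with 4-chlorophenyl in place of 2-fluorophenyl on the nitrogen, this assay gives a number rather than a limit for the first time, which yields a readable step at this position: an at least 1.5-fold lower number from compound 3 to compound 4 (0.18 log units; that floor lies within the scatter) is what the change gives. Against the other two compounds, chloro in place of fluoro on an aromatic carbon gives an at least 1.5-fold lower number from compound 2 to compound 4 (0.18 log units; that floor lies within the scatter), and 4-chlorophenyl in place of 2-methoxyphenyl gives an at least 1.5-fold lower number from compound 1 to compound 4 (0.18 log units; that floor lies within the scatter). From the compounds shown here alone, each of these steps is only a floor, so its true size stays open, and the steps among compound 1, compound 2 and compound 3 still cannot be read because those three share one limit: the limit of > 50000 nM in this assay, at which 3 of the 4 values shown sit.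

Going by these compounds, whether a bromine or a methyl in place of the chloro would bring the value further from that limit remains open. Also open, on these data alone, is what an amine or a carboxylic acid on this same aromatic ring would do in this assay.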